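From Cyclopentyl Amide to 4-Fluorophenyl Amide

The compounds below may be only part of what the source reports. "The series", "measured", "known", "first", "only" and "open" are said of these compounds alone.

Measured compounds:
Compound 1, `CC(C)C(=O)N1CCCn2nc(COc3ccccc3)cc21`: 59%
Compound 2, `O=C(C1CCCC1)N1CCCn2nc(COc3ccccc3)cc21`: 41%

In a functional assay on HEK293 cells for positive allosteric modulation of metabotropic glutamate receptor 5 (Homo sapiens), read by calcium flux (on this read-out lower numbers stand for smaller maximal responses and higher numbers for larger maximal responses), compound 1 gives 59%. Compound 2 sits at the lower of the two numbers shown: in this assay compound 2 gives 41%, and the only other measured compound, compound 1, lies higher by a margin beyond the scatter, as the step of a number 18 percentage points lower from compound 1 to compound 2 (beyond the scatter) shows. Compound 3, `O=C(c1ccc(F)cc1)N1CCCn2nc(COc3ccccc3)cc21`, has not yet been measured. Its difference from compound 2 is 4-fluorophenyl in place of cyclopentyl on a carbonyl carbon.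

Among the compounds with values here, the one measured step, a number 18 percentage points lower from compound 1 to compound 2 (beyond the scatter), compares two non-aromatic carbon groups on the carbonyl carbon; no measured pair shows what an aromatic ring such as 4-fluorophenyl does in that place. The measured step therefore bears only loosely on the change from compound 2 to compound 3, and the direction of the next step is open. Compound 3 is estimated at 48%, within the range 25% to 75%, which means an expected step of a number 7 percentage points higher from compound 2 to compound 3 (within the scatter), small against the wide uncertainty.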

Compound 3, largest response reached (reported as percent of maximum), in percent of the reference or control that the assay uses: 63%
Beside the measured number, compound 3's estimate is 15 percentage points below it; measured number inside the range.
By their numbers in this assay, from the lowest: compound 2; then compounds 1 and 3 (each within the scatter of the next).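

In this assay, the carbonyl carbon bound to the amide-type nitrogen in a ring now carries an aromatic ring, and 4-fluorophenyl in place of cyclopentyl gives a number 22 percentage points higher from compound 2 to compound 3 (beyond the scatter), showing that the lower maximal response of compound 2 does not extend to every larger group in this place. Set against the isopropyl amide, 4-fluorophenyl gives a number 4 percentage points higher from compound 1 to compound 3 (within the scatter), so these two groups are not separated in this read-out, and among the three groups shown only cyclopentyl stands apart, with a response beyond the scatter from both of the others. No measurement among the data shown offers an explanation for these differences.

The compounds shown change the ring and introduce fluorine in one step, so a plain phenyl group on the same carbonyl carbon would be needed to tell the contribution of the aromatic ring from that of the fluorine. From the compounds shown here alone, how a pyridine ring or a cyclohexyl group would behave in this place also remains open, as does whether any group here can rise beyond the scatter of compound 1 and compound 3.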